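The source may report more compounds than this note shows. Statements on the series, on what has been measured and on what is new or still open speak of the compounds shown alone.

Measured so far in a functional assay on the whole organism with Mus musculus as the target; on this read-out higher numbers stand for an effect only at larger amounts of compound and lower numbers for an effect already at smaller amounts:

Compound 1 `NC(=O)Cn1c(-c2ccc(Br)cc2)nc2cccnc21` gives 17.8 mg/kg
Compound 2 `NC(=O)Cn1c(-c2ccc(C(F)(F)F)cc2)nc2cccnc21` gives 11.7 mg/kg
Compound 3 `CN(C)C(=O)Cn1c(-c2ccc(Br)cc2)nc2cccnc21` gives 7 mg/kg

Compound 3 and compound 2 lie within the scatter of each other, while a 2.5-fold lower number from compound 1 to compound 3 (0.41 log units; beyond the scatter) goes beyond it. That step has dimethylamino in place of amino on a carbonyl carbon, so it does not touch the aromatic ring.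

Compound 4 `Cc1ccc(-c2nc3cccnc3n2CC(=O)N(C)C)cc1` differs from compound 3 by methyl in place of bromo on an aromatic carbon, para to a large group (methyl in place of bromo on an aromatic carbon). Among the measured compounds shown here, the one measured step at that place is a 1.5-fold lower number from compound 1 to compound 2 (0.18 log units; within the scatter) with trifluoromethyl in place of bromo. On the strength of that step, no change beyond the scatter is expected in this assay in either direction. For the measured compounds named here, no measured compound carries methyl, so this expectation remains loose. The estimated step is a 1.1-fold higher number from compound 3 to compound 4 (0.06 log units; within the scatter) and it should not be read as a trend. Compound 4 is expected at 8 mg/kg with an estimated range from 4 mg/kg to 16 mg/kg on this read-out.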

Compound 4, dose for half-maximal effect: 4.7 mg/kg
Beside the measured number, compound 4's estimate is 1.7-fold (0.23 log units) above it; low and high end bracket the measured number.
By their numbers in this assay, from the lowest: compounds 4, 3, 2 and 1 (each within the scatter of the next, the first and the last beyond it).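

In this assay, the change from 4-bromophenyl to 4-methylphenyl gives a 1.5-fold lower number from compound 3 to compound 4 (0.17 log units; within the scatter). The earlier replacement of bromo at this position brought in trifluoromethyl, which still carries halogen, and it was read on the compounds with the plain amide. This step shows that a methyl, with no halogen at all, also stays within the scatter of bromo, here with the dimethylamino group on the carbonyl carbon. Nothing available explains why this position responds in this way.

Going by these compounds, it remains open whether a methoxy group, an amine or a carboxylic acid at this position would also stay within the scatter of bromo. Methyl and trifluoromethyl also remain to be compared with each other on the same amide.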